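Swapping methoxy for chloro on the pyrazoline aryl ring

This account rests on a few compounds, and the source may have more. Where it says the series, first, only, none or still open, it means among the compounds named here.

Measured so far:
compound 1 `COc1cc(C2CC(c3ccccc3)=NN2C(C)=O)ccc1OCc1cn(Cc2ccc([N+](=O)[O-])cc2)nn1`: 11%
compound 2 `COc1cc(C2CC(c3cc(OC)c(OC)c(OC)c3)=NN2C(C)=O)ccc1OCc1cn(Cc2ccc([N+](=O)[O-])cc2)nn1`: 85%
compound 3 `COc1ccc(C2=NN(C(C)=O)C(c3ccc(OCc4cn(Cc5ccc([N+](=O)[O-])cc5)nn4)c(OC)c3)C2)cc1`: 84%

In a functional assay on A549 cells (Homo sapiens) for inhibition, read by sulforhodamine B assay, tested at 100 uM (a higher number here means more inhibition of growth at the concentration tested, a lower number less inhibition of growth), compound 3 stands second highest of the three, a hair from compound 2 and well above compound 1. Compound 4 `COc1cc(C2CC(c3ccc(Cl)cc3)=NN2C(C)=O)ccc1OCc1cn(Cc2ccc([N+](=O)[O-])cc2)nn1` differs from compound 3 by chloro in place of methoxy on an aromatic carbon. Among the compounds with values here, two measured steps bear on this spot: a number 73 percentage points higher from compound 1 to compound 3 (beyond the scatter), and a number 74 percentage points higher from compound 1 to compound 2 (beyond the scatter); both show that a bare phenyl gives little inhibition while an oxygen-bearing substituent gives much. Whether chloro behaves like methoxy or like hydrogen is not shown by any measured pair, so the expected step of a number 29 percentage points lower from compound 3 to compound 4 (beyond the scatter) is a moderate decrease with wide uncertainty. Compound 4 is therefore estimated at 55%, within 15% to 90%.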

Compound 4, percent growth inhibition at one concentration: 0%
Compound 4: the middle estimate sits 55 percentage points above what was measured; the measured number lies below the stated range.
By their numbers in this assay, from the lowest: compound 4; then compound 1; then compounds 3 and 2 (each within the scatter of the next).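

In this assay, a chloro at this spot does not stand in for methoxy: 4-chlorophenyl falls far short of 4-methoxyphenyl (a number 84 percentage points lower from compound 3 to compound 4 (beyond the scatter)) and of 3,4,5-trimethoxyphenyl (a number 85 percentage points lower from compound 2 to compound 4 (beyond the scatter)). Nor does chloro match hydrogen, as the number drops further (a number 11 percentage points lower from compound 1 to compound 4 (beyond the scatter)), which places it on the low side of the bare phenyl rather than near methoxy. Nothing measured here explains this difference. From the compounds shown here alone, whether an ethoxy, a hydroxyl or an amine in the same place would follow methoxy or chloro remains open.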